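A few compounds are considered here, and "the series" means these few. Any claim that something is new, unique, unknown or untested is made for them only; others in the source may bear on it.

For the measured compounds named here, compound 1 `O=C1N(CCCCCCCOc2ccc(C(F)(F)F)cc2)CCN1c1ccncc1` is the one with a number: in a functional assay on cells (Homo sapiens) for cytotoxicity (a lower number here means that less compound is tolerated, a higher number that more compound is tolerated), compound 1 gives 6250 nM. Compound 2 `O=C1N(CCCCCCCOc2ccc(Cl)cc2)CCN1c1ccncc1` reaches only the limit of this assay, at > 25000 nM. Between them the change trifluoromethyl in place of chloro on an aromatic carbon made a step of an at least 4.0-fold lower number from compound 2 to compound 1 (0.60 log units; beyond the scatter). Compound 3 `O=C1N(CCCCCCOc2ccc(Cl)cc2)CCN1c1cccnc1` likewise sits at the limit of this assay, giving > 25000 nM. The difference between the core of compound 3 and the core of compound 2 is not broken down here. Compound 4 `O=C1N(CCCCCCOc2ccc(C(F)(F)F)cc2)CCN1c1cccnc1`, not yet measured, carries the same change: trifluoromethyl in place of chloro on an aromatic carbon. For compound 4 a step of an at least 3.1-fold lower number from compound 3 to compound 4 (0.49 log units; beyond the scatter) is expected, beside the earlier at least 4.0-fold lower number from compound 2 to compound 1 (0.60 log units; beyond the scatter) that the same change produced, though the limit of > 25000 nM in this assay, at which 2 of the 3 values shown sit, leaves the starting point of compound 3 open. Compound 4 is therefore estimated at 8000 nM, between 3000 nM and 30000 nM.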

Compound 4, half-maximal cytotoxic concentration: > 25000 nM
Compound 4 ended at the assay's limit; the forecaster's own chance of this, stated with the estimate: 30%; middle value at least 3.1-fold (0.49 log units) from the limit.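

The step from compound 3 to compound 4 cannot be read, because both compounds stop at a limit: the limit of > 25000 nM in this assay, at which 3 of the 4 values shown sit.

On these data alone, whether trifluoromethyl in place of chloro lowers the number for compound 3, as it did for compound 2, stays open.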